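Nitro removal on the thiourea aryl ring

This account rests on a few compounds, and the source may have more. Where it says the series, first, only, none or still open, it means among the compounds named here.

Measured so far:
compound 1 `CC1(C)CC(NC(=S)Nc2ccc([N+](=O)[O-])cc2)c2cc(Cl)ccc2O1` — 4000 nM
compound 2 `CC1(C)CC(NC(=S)Nc2cccc([N+](=O)[O-])c2)c2cc(Cl)ccc2O1` — 4000 nM

In a functional assay on T98G cells (Homo sapiens) for inhibition, read by MTT assay, with a stated time of 72 h (a higher number here means a weaker inhibitor, a lower number a stronger inhibitor), compound 1 gives 4000 nM. In this assay compound 2 gives 4000 nM, level with compound 1 at the digits shown; the two values lie within the scatter of each other, so the two measured compounds show only that shifting the nitro group on the aryl ring leaves the read-out unchanged. Among the compounds with values here, no step between measured compounds is available.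

Compound 3 `CC1(C)CC(NC(=S)Nc2ccccc2)c2cc(Cl)ccc2O1` is not yet measured. Relative to compound 2 it carries hydrogen in place of nitro on an aromatic carbon. With both nitro-bearing compounds sitting at the same value, the nitro group gives no sign of carrying the inhibition, and the expected step is a 1.3-fold higher number from compound 2 to compound 3 (0.10 log units; within the scatter), a slight weakening at most, likely not beyond the scatter. Compound 3 is therefore estimated at 5000 nM, with a range of 2000 nM to 15000 nM.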

Compound 3, half-maximal inhibitory concentration: 37000 nM
Compound 3: the middle estimate sits 7.4-fold (0.87 log units) below what was measured; measured number outside the range, above it.
By their numbers in this assay, from the lowest: compounds 1 and 2 (each within the scatter of the next); then compound 3.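

In this assay, hydrogen in place of nitro on an aromatic carbon gives a 9.3-fold higher number from compound 2 to compound 3 (0.97 log units; beyond the scatter), and the same change gives a 9.3-fold higher number from compound 1 to compound 3 (0.97 log units; beyond the scatter). Compounds 1 and 2 showed only that the two nitro placements read level; the unsubstituted ring of compound 3 now shows that having the nitro group on this ring matters, whichever of those two places it occupies. No measurement shown here offers a reason for this loss.

As far as these compounds go, whether the nitro group itself is required, or another group on the same aromatic carbon would serve as well, such as a nitrile, an amine or a carboxylic acid, stays open. Also open, from the compounds shown here alone, is whether the same change would give a step of similar size with a different group in place of the chlorine on the shared core.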